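Anilide ACAT inhibitors: ethoxy against isopropyl on two cores

The source may hold more compounds than are shown below. What is called first, only, known or untested is meant among the compounds shown, and "the series" means these compounds.

Four anilides are compared in an assay on microsomes from intestine for inhibition of acyl-CoA:cholesterol acyltransferase (Oryctolagus cuniculus); a higher number here means a weaker inhibitor, a lower number a stronger inhibitor. Compound 1 `CCCCCCCC/C=C/CCCCCCCC(=O)Nc1c(C)cccc1OCC` carries an ethoxy group on the aromatic ring and gives 15 nM in this assay. Compound 2 `CCCCCCCC/C=C/CCCCCCCC(=O)Nc1c(C)cccc1C(C)C` differs from it by the change isopropyl in place of ethoxy on an aromatic carbon and gives 23 nM; the step of a 1.5-fold higher number from compound 1 to compound 2 (0.19 log units; within the scatter) leaves the two within the usual scatter of this assay, so nothing can be said about their order.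

Compound 3 `CCCCCCCCCCC(C)(C)C(=O)Nc1c(C)cccc1OCC` has a different acyl part; the difference between its core and the core of compound 1 is not broken down here. In this assay compound 3 gives 180 nM, the highest of the three numbers, and its gaps to compound 1 and to compound 2 both lie beyond the scatter.

Compound 4 `CCCCCCCCCCC(C)(C)C(=O)Nc1c(C)cccc1C(C)C` is the counterpart of compound 3 in the same way that compound 2 is the counterpart of compound 1: it carries the change (isopropyl in place of ethoxy on an aromatic carbon), the same change as before, at a place described in the same words. In this assay compound 4 has not yet been measured. Since the same change in a 1.5-fold higher number from compound 1 to compound 2 (0.19 log units; within the scatter) stayed within the scatter, compound 4 is expected to sit close to compound 3, with a step of about a 1.4-fold higher number from compound 3 to compound 4 (0.14 log units; within the scatter). Compound 4 is therefore estimated at 250 nM in this assay, expected to fall between 90 nM and 700 nM.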

Compound 4, half-maximal inhibitory concentration: 240 nM
Compound 4: middle estimate off by 1.0-fold (0.02 log units), on the high side; the range from low to high includes it.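

In this assay the exchange of ethoxy for isopropyl on an aromatic carbon gives a 1.3-fold higher number from compound 3 to compound 4 (0.12 log units; within the scatter) on this second core. Across the two cores shown, the exchange reads the same, and no difference between its two steps can be made out: the same change on two cores in this assay, a 1.5-fold higher number (0.19 log units; within the scatter) from compound 1 to compound 2 and a 1.3-fold higher number (0.12 log units; within the scatter) from compound 3 to compound 4, 1.2-fold (0.06 log units) apart, within the scatter of two such steps

Within the data shown here, this shows that, for these two pairs and in this one assay, ethoxy and isopropyl at this place cannot be told apart, but it gives no order within either pair and does not establish that the two groups are interchangeable on any core beyond these two, or in any other kind of measurement.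

The compounds shown leave open how other groups at this same aromatic carbon, such as methoxy, tert-butyl, an amine or a longer alkoxy chain, would compare with ethoxy and isopropyl. They also leave open whether the exchange would read the same way on a different acyl part, for instance a shorter chain or one ending in a carboxylic acid, where the agreement seen on these two cores may or may not hold.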